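Lengthening the chain from compound 2 to compound 3

The compounds below may be only part of what the source reports. "The series", "measured", "known", "first", "only" and "open" are said of these compounds alone.

Compound 1 `CCCCCCC(CCO)n1cnc2c(Cl)ncnc21`: 16700 nM
Compound 2 `CCCCCCCC(CCO)n1cnc2c(Cl)ncnc21`: 3630 nM

Both values come from a functional assay on SW480 cells (Homo sapiens) for antiproliferative activity, read by MTT assay, with a stated time of 48 h; on this read-out lower numbers stand for stronger inhibition and higher numbers for weaker inhibition. Of the two measured compounds, compound 2 gives the lower number, at 3630 nM, and so shows the stronger inhibition. Compound 3 `CCCCCCCCCCCC(CCO)n1cnc2c(Cl)ncnc21` has not yet been measured. It differs from compound 2 as follows: butyl in place of hydrogen on a saturated chain carbon, eight bonds along the chain from an aromatic nitrogen.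

Among the compounds with values here, only one measured step bears on this change: a 4.6-fold lower number from compound 1 to compound 2 (0.66 log units; beyond the scatter). That step, methyl in place of hydrogen on a saturated chain carbon, is modest but beyond the scatter. It points towards a lower number as the chain grows. However, it is a single step, and no chain longer than that of compound 2 has been measured, so the trend may not carry on at the same rate. A modest further fall in this assay is therefore expected, with wide uncertainty. The expected change is a 2.8-fold lower number from compound 2 to compound 3 (0.45 log units; beyond the scatter). The estimate for compound 3 is 1300 nM, with an expected range from 350 nM to 5000 nM.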

Compound 3, half-maximal inhibitory concentration: 5290 nM
Beside the measured number, compound 3's estimate is 4.1-fold (0.61 log units) below it; measured number above the stated range.
By their numbers in this assay, from the lowest: compounds 2 and 3 (each within the scatter of the next); then compound 1.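

In this assay, the added butyl on a saturated chain carbon, eight bonds along the chain from an aromatic nitrogen, gives a 1.5-fold higher number from compound 2 to compound 3 (0.16 log units; within the scatter) and so does not extend the earlier step of a 4.6-fold lower number from compound 1 to compound 2 (0.66 log units; beyond the scatter) to this longer chain. The pentyl change still gives a 3.2-fold lower number from compound 1 to compound 3 (0.50 log units; beyond the scatter) and so shows that a longer chain on the shared core can stay clear of the number for compound 1 even though compound 3 cannot be separated from compound 2. Across these three compounds, the number therefore does not keep falling as the chain grows, and compound 3 goes against any such steady trend, while no measured information on the compounds accounts for this result.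

The compounds shown leave open whether a chain of intermediate length, or a longer chain than that of compound 3, would separate itself from compound 2 in this assay at all. They also leave open how an amine or a carboxylic acid in place of the butyl, on the same saturated chain carbon, would read in this cell line.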